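The source may hold more compounds than are shown below. What is called first, only, known or untested is meant among the compounds shown, and "the series" means these compounds.

Compounds measured so far:
- compound 1, `COc1cc2c(Nc3ccc(C#N)cc3)ncnc2cc1OCCCN1CCCC1`: in a functional assay on MCF7 cells (Homo sapiens) for antiproliferative activity, read by MTT assay, with a stated time of 72 h (a higher number here means a weaker inhibitor, a lower number a stronger inhibitor), compound 1 gives 16200 nM
- compound 2, `COc1cc2c(Nc3ccc(C#N)cc3)ncnc2cc1OCCCN1CCC(CO)CC1`: in this assay compound 2 gives 35100 nM

Compound 2 holds the highest of the two numbers measured in this assay; its nearest neighbour is compound 1, reached by the step of a 2.2-fold higher number from compound 1 to compound 2 (0.34 log units; beyond the scatter), a modest change that lies beyond the scatter.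

Compound 3, `COc1cc2c(Nc3ccc(C#N)cc3)ncnc2cc1OCCCN1CCC(c2ccccc2)CC1`, is not yet measured. It differs from compound 2 in one place: phenyl in place of hydroxymethyl on a saturated ring carbon.

For the measured compounds named here, only one measured step exists, and it concerns a different change at the amine end of the chain: a 2.2-fold higher number from compound 1 to compound 2 (0.34 log units; beyond the scatter). Going by the values given here, no measured pair speaks to an exchange of hydroxymethyl for phenyl on the piperidine ring, so nothing here sets the direction of the new step. Among the compounds with values here, the one step recorded was modest, and a change of comparable size, in either direction or none beyond the scatter, is the reasonable expectation. Compound 3 is accordingly estimated at 25000 nM in this assay, with a range from 6000 nM to 100000 nM, which corresponds to an expected step of a 1.4-fold lower number from compound 2 to compound 3 (0.15 log units; within the scatter).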

Compound 3, half-maximal inhibitory concentration: 9800 nM
Estimate against measurement, compound 3: 2.6-fold (0.41 log units) above, within the range that was stated.
By their numbers in this assay, from the lowest: compounds 3 and 1 (each within the scatter of the next); then compound 2.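

In this assay the ring carbon three ring bonds from the ring nitrogen proves responsive to its substituent: phenyl in place of hydroxymethyl gives a change beyond the scatter (a 3.6-fold lower number from compound 2 to compound 3 (0.55 log units; beyond the scatter)), so a group of six carbon atoms in one aromatic ring is tolerated there and the number falls. The exchange of pyrrolidin-1-yl for 4-phenylpiperidin-1-yl stays within the scatter (a 1.7-fold lower number from compound 1 to compound 3 (0.22 log units; within the scatter)), so the higher number of compound 2 cannot be read as a feature of the piperidine ring alone, since compound 3 carries that ring too and is not separated from compound 1. Nothing available explains either step or connects it to any measured property of these groups.

As far as these compounds go, whether a smaller 4-methylpiperidin-1-yl, a 4-benzylpiperidin-1-yl or a carboxylic acid on the same ring carbon would behave like phenyl or like hydroxymethyl remains open. Also open, from the compounds shown here alone, is whether a shorter or longer chain to the ring oxygen, or a different amine at its end such as morpholine, would move the number well away from the level of compound 3 (9800 nM).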